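The source may report more compounds than this note shows. Statements on the series, on what has been measured and on what is new or still open speak of the compounds shown alone.

Working notes on the series in an assay for inhibition of kynurenine 3-monooxygenase (Homo sapiens), read by mass spectrometry, with a stated time of 1 h; a higher number here means a weaker inhibitor, a lower number a stronger inhibitor.

Compound 1 `Cc1ccc([C@@H](C)Oc2cc3onc(CCC(=O)O)c3cc2Cl)nc1` gives in this assay 3.16 nM. Compound 2 `CCc1cc2oc(=O)n(CCC(=O)O)c2cc1Cl` gives in this assay 10 nM. Of the two numbers recorded, compound 1 holds the lower one; compound 2 sits higher by a gap that lies beyond the usual scatter of repeat measurements. For the measured compounds named here, compound 2 is built on a different core and differs from compound 1 in more than one place, so no single step between the two is defined; the two values are simply compared as they stand.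

The next compound follows from compound 1. Compound 3 `Cc1ccc([C@@H](C)Oc2cc3onc(CCC(=O)O)c3cc2Cl)nn1` carries the change (6-methylpyridazin-3-yl in place of 5-methylpyridin-2-yl on a saturated chain carbon bound to an oxygen on an aromatic ring and a saturated chain carbon). The acid-bearing chain and the chlorine on the shared core of compound 1 remain. Going by the values given here, no pair of measured compounds shows this exchange, so its size is not known from the data; the expectation is a step from compound 1 to compound 3 of at most modest size, either direction, most likely within the scatter. For compound 3 the expected step is a 1.6-fold higher number from compound 1 to compound 3 (0.20 log units; within the scatter). Compound 3 is therefore estimated at 5 nM, with a range from 1.8 nM to 16 nM.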

Compound 3, half-maximal inhibitory concentration: 2 nM
The estimate for compound 3 lay 2.5-fold (0.40 log units) above the measured number; the measured number falls inside the stated range.
By their numbers in this assay, from the lowest: compounds 3 and 1 (each within the scatter of the next); then compound 2.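

In this assay, for the compounds shown here, the exchange of 5-methylpyridin-2-yl for 6-methylpyridazin-3-yl on a saturated chain carbon bound to an oxygen on an aromatic ring and a saturated chain carbon gives a 1.6-fold lower number from compound 1 to compound 3 (0.20 log units; within the scatter) and is the first step that can be read at one place. At this place, then, a ring with 2 hetero atoms and 2 hydrogen-bond acceptors stands level in this assay with a ring with 1 hetero atom and 1 hydrogen-bond acceptor, and the low-nanomolar values of the series are kept through the exchange. Nothing available bears on why the two rings give values within the scatter of each other.

From the compounds shown here alone, with only these two rings compared on this carbon, it stays open how a phenyl or a pyrimidine ring would compare, or a trifluoromethyl group in place of the methyl on the ring. The acid-bearing chain and the chlorine are the same in compound 1 and compound 3, so a tetrazole in place of the carboxylic acid, or a bromine or nitrile in place of the chlorine, also remains an open question.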